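An Isoquinolin-4-yl Sulfonyl Variant of Compound 3

A few compounds are considered here, and "the series" means these few. Any claim that something is new, unique, unknown or untested is made for them only; others in the source may bear on it.

Three compounds share one core and differ in the aryl group on the sulfonyl sulfur and in one ring substituent. In an assay on HEK293 cells for displacement of a labelled ligand from 5-hydroxytryptamine receptor 6 (Homo sapiens), read by scintillation counting (on this read-out lower numbers stand for stronger inhibition and higher numbers for weaker inhibition), compound 1 `O=S(=O)(c1cncc2ccccc12)n1cc(C2=CCNCC2)c2cc(Cl)ccc21` gives 18 nM. In this assay compound 2 `COc1ccc2c(c1)c(C1=CCNCC1)cn2S(=O)(=O)c1cnc2ccccc2c1` gives 8 nM. In this assay compound 3 `COc1ccc2c(c1)c(C1=CCNCC1)cn2S(=O)(=O)c1cc2ccccc2cn1` gives 6 nM, the lowest of the three numbers; compound 2 lies within the scatter of it, compound 1 beyond it. Among the measured compounds shown here, the only single change measured on the sulfonyl aryl group is a 1.3-fold lower number from compound 2 to compound 3 (0.12 log units; within the scatter), which lies within the scatter.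

Compound 4 `COc1ccc2c(c1)c(C1=CCNCC1)cn2S(=O)(=O)c1cncc2ccccc12` carries isoquinolin-4-yl in place of isoquinolin-3-yl on a sulfonyl sulfur. For the measured compounds named here, no measured step covers this exact change. Compound 1 also bears isoquinolin-4-yl, but it differs from compound 2 in two places. Compound 1 gives 18 nM and compound 2 gives 8 nM; these two values can only be noted side by side. Going by the values given here, since the one aryl swap that was measured stayed within the scatter, compound 4 is expected to show a 1.7-fold higher number from compound 3 to compound 4 (0.22 log units; within the scatter), a step not clearly beyond the scatter. Compound 4 is therefore estimated at 10 nM, with a range from 4 nM to 30 nM.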

Compound 4, inhibition constant: 3 nM
Estimate against measurement, compound 4: 3.3-fold (0.52 log units) above; the measured number lies below the stated range.
By their numbers in this assay, from the lowest: compounds 4, 3 and 2 (each within the scatter of the next, the first and the last beyond it); then compound 1.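

In this assay, the move of the sulfonyl attachment within the isoquinoline gives a 2.0-fold lower number from compound 3 to compound 4 (0.30 log units; within the scatter), so isoquinolin-4-yl and isoquinolin-3-yl on the sulfonyl sulfur remain within the scatter of each other. Isoquinolin-4-yl in place of quinolin-3-yl gives a 2.7-fold lower number from compound 2 to compound 4 (0.43 log units; beyond the scatter), an aryl change on the sulfur that goes beyond the scatter, which the one aryl step known earlier did not. With isoquinolin-4-yl held fixed, methoxy in place of chloro on an aromatic carbon now reads directly as a 6.0-fold lower number from compound 1 to compound 4 (0.78 log units; beyond the scatter), also beyond the scatter. Nothing measured here explains these steps.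

The compounds shown leave open how a fluoro or a hydroxy group would read in place of methoxy on that aromatic carbon. They also leave open how a naphthyl group, with only carbon in its rings, would read on the sulfonyl sulfur.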